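From Methyl to 2-Phenylethenyl on the Shared Core

This account rests on a few compounds, and the source may have more. Where it says the series, first, only, none or still open, it means among the compounds named here.

Of the compounds shown here, two have so far been tested in a functional assay on KB cells (Homo sapiens) for cytotoxicity, read by MTT assay, with a stated time of 72 h; a higher number here means that more compound is needed for the effect, a lower number that less compound is needed. Compound 1, `COc1cccc(Nc2cc(-c3ccccc3)oc(=O)c2)c1`, gives 0.49 uM in this assay. Compound 2, `COc1ccc(Nc2cc(C)oc(=O)c2)cc1`, stands differently: in this assay compound 2 gives > 30 uM, and this is a limit of the assay rather than a measured number. Compound 2 therefore sits at the limit of > 30 uM in this assay, at which 1 of the 2 values shown sits. Among the measured compounds shown here, compound 1 and compound 2 differ in more than one place, so their values show only that compound 1 returned a measured concentration while compound 2 did not.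

Compound 3, `COc1ccc(Nc2cc(/C=C/c3ccccc3)oc(=O)c2)cc1`, has not yet been measured. It differs from compound 2 by 2-phenylethenyl in place of methyl on an aromatic carbon. For the measured compounds named here, the only measured number in this set belongs to compound 1, which carries an additional aromatic ring on the shared core and gives 0.49 uM. On that slender basis the step from compound 2 to compound 3 is expected to lower the number well beyond the usual scatter, estimated as an at least 10-fold lower number from compound 2 to compound 3 (1.00 log units; beyond the scatter). Compound 3 is accordingly estimated at 3 uM, within a range from 0.5 uM to 30 uM.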

Compound 3, concentration for half-maximal effect: 0.15 uM
Estimate against measurement, compound 3: 20-fold (1.30 log units) above, and the stated range ends above it.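

Among the compounds shown here, with only one place changed, this is the first comparison in the set that can be read, and in this assay putting 2-phenylethenyl in place of methyl on the aromatic carbon next to the ring oxygen gives an at least 200-fold lower number from compound 2 to compound 3 (2.30 log units; beyond the scatter) and so shows that the number responds strongly to what sits at this position on the shared core. As far as these compounds go, compound 2 stands at a limit of the assay and not at a measured number, so the step is a minimum and its true size stays unknown: the limit of > 30 uM in this assay, at which 1 of the 3 values shown sits.

The change brings in a six-membered aromatic ring and a double bond outside aromatic rings together, so this single step shows the effect of the whole 2-phenylethenyl group and does not divide it between those two parts.

The compounds shown leave open whether the ring, the double bond or both are needed for the lower number, a question that a saturated two-carbon link to the same ring could address. They also leave open how quite different groups at this position, such as an amine, a carboxylic acid or a longer alkyl chain, would compare.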